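Adding a Methoxy Group to Compound 1

A few compounds are considered here, and "the series" means these few. Any claim that something is new, unique, unknown or untested is made for them only; others in the source may bear on it.

In a functional assay on MCF7 cells (Homo sapiens) for antiproliferative activity, read by sulforhodamine B assay, with a stated time of 72 h (on this read-out higher numbers stand for weaker inhibition and lower numbers for stronger inhibition), compound 1 (`Fc1ccc(/C=C\c2cc3ccccc3nc2Cl)cc1`) gives 20300 nM, within the scatter of both other measured compounds. Compound 2 (`Fc1ccc(/C=C/c2cc3ccccc3nc2Cl)cc1`) gives 15100 nM, and compound 3 (`Fc1ccc(/C=C\c2cc3ccc(Cl)cc3nc2Cl)cc1`) gives 16900 nM. Compound 4 (`COc1ccc2nc(Cl)c(/C=C\c3ccc(F)cc3)cc2c1`) has methoxy in place of hydrogen on an aromatic carbon. The double-bond configuration change gives a 1.3-fold lower number from compound 1 to compound 2 (0.13 log units; within the scatter), but it bears little on this replacement. The closer precedent, chloro in place of hydrogen on an aromatic carbon, gives a 1.2-fold lower number from compound 1 to compound 3 (0.08 log units; within the scatter). No step beyond the scatter is therefore expected in this assay, and the expected step is a 1.2-fold lower number from compound 1 to compound 4 (0.08 log units; within the scatter). Compound 4 is estimated at 17000 nM, with an expected range of 8000 nM to 32000 nM.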

Compound 4, half-maximal inhibitory concentration: 8970 nM
Compound 4: the middle estimate sits 1.9-fold (0.28 log units) above what was measured; measured number inside the range.
By their numbers in this assay, from the lowest: compounds 4, 2, 3 and 1 (each within the scatter of the next, the first and the last beyond it).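

In this assay, methoxy in place of hydrogen on an aromatic carbon gives a 2.3-fold lower number from compound 1 to compound 4 (0.35 log units; beyond the scatter) and so is the only change from compound 1 shown that passes the scatter, if modestly. The chloro change, with a 1.2-fold lower number from compound 1 to compound 3 (0.08 log units; within the scatter), and the double-bond change, with a 1.3-fold lower number from compound 1 to compound 2 (0.13 log units; within the scatter), both stay within it. Nothing available accounts for the methoxy step.

From the compounds shown here alone, whether an ethoxy group, a hydroxyl group or an amine on this carbon would give a similar step remains open. So does whether methoxy would act alike in compound 2, with its double bond drawn E.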